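The compounds below may be only part of what the source reports. "The series", "measured", "known", "first", "only" and "open" are said of these compounds alone.

Compound 1 `CCN1CCc2c(sc(NC(=O)Nc3ccc(Cl)cc3)c2C(N)=O)C1` gives 3120 nM in a functional assay (strain AB) with Danio rerio as the target, read by microscopy, with a stated time of 1 h; a lower number here means that less compound is needed, a higher number that more compound is needed for the effect.
Compound 2 `CCN1CCc2c(sc(NC(=O)Nc3ccc(Cl)cc3)c2C#N)C1` shows > 25000 nM there.
Compound 3 `CC(C)(C)OC(=O)N1CCc2c(sc(NC(=O)Nc3ccc(Cl)cc3)c2C(N)=O)C1` shows > 25000 nM there.

The value for compound 2 is a limit of the assay, not a measured number: compound 2 stands at the limit of > 25000 nM in this assay, at which 2 of the 3 values shown sit. Compound 3 stands at the same limit. Only compound 1 has a numerical value, so the shared core with an ethyl on the ring nitrogen and a carbamoyl on the thiophene carbon is the one point of reference.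

Compound 4 `CCN1CCc2c(sc(NC(=O)Nc3ccc(Cl)cc3)c2C(=O)N2CCOCC2)C1` differs from compound 2 in one place: (morpholin-4-yl)carbonyl in place of cyano on an aromatic carbon.

Two measured steps exist. The step of an at least 8.0-fold higher number from compound 1 to compound 3 (0.90 log units; beyond the scatter) concerns the ring nitrogen, which compound 4 leaves exactly as in compound 2, so it does not bear on this change. The step of an at least 8.0-fold higher number from compound 1 to compound 2 (0.90 log units; beyond the scatter) does bear on it: it shows that exchanging a carbamoyl for a cyano pushed the value from a measurable number out to the limit. Compound 4 moves in the opposite direction, putting a carbonyl-bearing group back in place of the cyano, though with a morpholine ring where the primary amide carried its hydrogens. A downward step is therefore expected, roughly undoing the earlier loss, an at least 4.1-fold lower number from compound 2 to compound 4 (0.61 log units; beyond the scatter). Compound 4 is estimated at 6000 nM, with a range from 1500 nM to 25000 nM.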

Compound 4, half-maximal effective concentration: > 25000 nM
Compound 4 was reported as a limit; the forecaster's own chance of this, stated with the estimate: 30%; middle value at least 4.1-fold (0.61 log units) away from the limit.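

The reading for compound 4 in this assay is a limit of the assay, not a number, and it joins the other compounds already there: the limit of > 25000 nM in this assay, at which 3 of the 4 values shown sit. Restoring a carbonyl at this aromatic carbon therefore does not by itself bring back a measurable value, and replacing the amino group of the primary amide with morpholin-4-yl gives an at least 8.0-fold higher number from compound 1 to compound 4 (0.90 log units; beyond the scatter). Among the compounds that keep the ethyl on the ring nitrogen, only the primary amide of compound 1 has a numerical value so far, whereas the earlier compounds could not show that a carbonyl alone falls short; the step between compound 2 and compound 4 cannot be read, as both sit at the limit.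

The compounds shown leave open how much change the amide at this carbon can take, since a methylamide, a dimethylamide or a carboxylic acid would fill the wide gap between the primary amide and the morpholine amide. On these data alone, how far compound 2 and compound 4 lie beyond the limit, and so whether they differ at all, also remains unknown.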